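Nitro in place of carbamoyl: cytotoxicity in a urea series

The compounds below may be only part of what the source reports. "The series", "measured", "known", "first", "only" and "open" are said of these compounds alone.

Three ureas on a shared core have been measured in an ADME assay on HEK293 cells (Homo sapiens) for cytotoxicity, with a stated time of 72 h; a higher number here means that more compound is needed for the effect, a lower number that less compound is needed. Compound 1 `Cc1cc(NC(=O)Nc2ccc(N)cc2)c2ccccc2n1` gives > 25000 nM, which is a limit of the assay rather than a number. Compound 2 `Cc1cc(NC(=O)Nc2ccccc2F)c2ccccc2n1` likewise returns > 25000 nM, again a limit. The step that the two limits leave unreadable from compound 1 to compound 2 therefore cannot be read. Compound 3 `Cc1cc(NC(=O)Nc2cccc(C(N)=O)c2)c2ccccc2n1` gives > 25000 nM, also a limit; it stands with the other two at the limit of > 25000 nM in this assay, at which 3 of the 3 values shown sit, and no ranking among the three values is possible.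

Compound 4 `Cc1cc(NC(=O)Nc2cccc([N+](=O)[O-])c2)c2ccccc2n1` differs from compound 3 by nitro in place of carbamoyl on an aromatic carbon. Within the data shown here, no measured step touches the nitro or the carbamoyl group, and the one measured step in this assay is unreadable, so nothing points to a change beyond the scatter. Given that compound 3 sits at the limit of > 25000 nM in this assay, at which 3 of the 3 values shown sit, compound 4 is expected to return a limit again, with an estimated step that the limit leaves unreadable from compound 3 to compound 4. The estimate for compound 4 is 30000 nM, with a range from 15000 nM to 80000 nM.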

Compound 4, half-maximal effective concentration: > 25000 nM
Compound 4 was reported as a limit; the forecaster's own chance of this, stated with the estimate: 85%; the middle value is on the limit's open side.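

Compound 3 and compound 4 both return only a limit in this assay, so the step for nitro in place of carbamoyl cannot be read. The compounds shown leave open how any of these ureas would rank on a readable value, with all results at one limit: the limit of > 25000 nM in this assay, at which 4 of the 4 values shown sit.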